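Branching the ether chain in a guanidine acylsulfone series

This account rests on a few compounds, and the source may have more. Where it says the series, first, only, none or still open, it means among the compounds named here.

Compound 1 `CCSc1cc(C)c(C(=O)N=C(N)N)cc1S(C)(=O)=O`: 5.9 nM
Compound 2 `CCCSc1cc(C)c(C(=O)N=C(N)N)cc1S(C)(=O)=O`: 6.8 nM
Compound 3 `CCOc1cc(C)c(C(=O)N=C(N)N)cc1S(C)(=O)=O`: 19 nM

In a functional assay for inhibition of sodium/hydrogen exchanger (Oryctolagus cuniculus) (on this read-out lower numbers stand for stronger inhibition and higher numbers for weaker inhibition), compound 1 gives 5.9 nM and compound 2 gives 6.8 nM. Compound 3 gives 19 nM, and the step of a 3.2-fold higher number from compound 1 to compound 3 (0.51 log units; beyond the scatter) rests on (ethoxy in place of ethylsulfanyl on an aromatic carbon). Compound 4 `Cc1cc(OC(C)C)c(S(C)(=O)=O)cc1C(=O)N=C(N)N` is not yet measured; it differs from compound 3 by methyl in place of hydrogen on a saturated chain carbon bound to an oxygen on an aromatic ring and a saturated chain carbon. The same kind of change, seen as methyl in place of hydrogen on a saturated chain carbon, two bonds along the chain from a sulfur, produced a 1.2-fold higher number from compound 1 to compound 2 (0.06 log units; within the scatter), though there the place differs: the new carbon sits two bonds along the chain from a sulfur, whereas in compound 4 it sits on a carbon bound to an oxygen on an aromatic ring and a saturated chain carbon. On that one precedent, compound 4 is expected to stay close to compound 3, with an estimated step of a 1.2-fold higher number from compound 3 to compound 4 (0.06 log units; within the scatter). The estimate for compound 4 is 22 nM, between 9 nM and 55 nM.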

Compound 4, half-maximal inhibitory concentration: 19 nM
Compound 4: middle estimate off by 1.2-fold (0.06 log units), on the high side; measured number inside the range.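

In this assay, among the compounds shown here, the methyl that turns ethoxy into isopropoxy gives no change at the digits printed from compound 3 to compound 4 (within the scatter), and the two instances of this change agree: the same change on two cores in this assay, a 1.2-fold higher number (0.06 log units; within the scatter) from compound 1 to compound 2 and no change at the digits printed (within the scatter) from compound 3 to compound 4, 1.2-fold (0.06 log units) apart, within the scatter of two such steps The change therefore carries between these two cores without a shift beyond the scatter, but this rests on only two pairs, with the methyl at a different place on the chain in each, and it shows nothing about other cores or larger groups. Isopropoxy does not close the gap to the sulfur-linked chains, with a 2.8-fold higher number from compound 2 to compound 4 (0.45 log units; beyond the scatter) and a 3.2-fold higher number from compound 1 to compound 4 (0.51 log units; beyond the scatter).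

Still open, as far as these compounds go, is whether a longer chain such as butoxy, or an amine, on that aromatic carbon would stay near compound 4 or come closer to compound 1.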